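From compound 3 to compound 4: one amide substituent

This account rests on a few compounds, and the source may have more. Where it says the series, first, only, none or still open, it means among the compounds named here.

Measured in a physicochemical assay for lipophilicity, at pH 7.4; on this read-out higher numbers stand for higher lipophilicity and lower numbers for lower lipophilicity:
Compound 1 `CNC(=O)c1cc(C(=O)N[C@H]2[C@@H]3C[C@H](O)C[C@@H]32)cc2c1OC[C@@]2(C)c1ccccc1`: 3.7
Compound 2 `CNC(=O)c1cc(C(=O)N[C@H]2[C@@H]3COC[C@@H]32)cc2c1OC[C@@]2(C)c1ccccc1`: 3.7
Compound 3 `CNC(=O)c1cc(C(=O)NC)c2c(c1)[C@](C)(c1ccccc1)CO2`: 3.4

In this assay compound 3 gives 3.4, a number that lies within the scatter of the values of both other measured compounds. The three therefore form a single group on this read-out, and no order among them can be claimed.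

The next compound is compound 4 `CNC(=O)c1cc(C(=O)N[C@H]2[C@@H]3C[C@@H](O)C[C@@H]32)cc2c1OC[C@@]2(C)c1ccccc1`, which has not yet been measured. Its change from compound 3 is a group of 7 heavy atoms (6 carbon, 1 oxygen; one three-membered non-aromatic ring of carbon only, one five-membered non-aromatic ring of carbon only) in place of one carbon atom, on an amide-type nitrogen. The methyl leaves, and the new group stands on the same amide-type nitrogen.

Among the measured compounds shown here, two measured steps bear on this change. The closer one is a number 0.30 log units lower from compound 1 to compound 3 (within the scatter). It involves a group of the same description, exchanged in the opposite direction. The second is a number 0.30 log units lower from compound 2 to compound 3 (within the scatter), where the group has 6 heavy atoms. A third step, no change at the digits printed from compound 1 to compound 2 (within the scatter), shows that exchanging one such group for the other left the number unchanged within the scatter.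

None of these steps goes beyond the scatter, so no step beyond the scatter is expected here. The expected size is a number 0.30 log units higher from compound 3 to compound 4 (within the scatter), an estimate that stays within the scatter. For compound 4 the estimated value in this assay is 3.7, with an expected range from 3.4 to 4.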

Compound 4, distribution coefficient: 3.3
The estimate for compound 4 lay 0.40 log units above the measured number; the whole stated range lies above it.
By their numbers in this assay, from the lowest: compounds 4, 3, 1 and 2 (each within the scatter of the next, the first and the last beyond it).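

In this assay, the result shows that the description of the group on the amide-type nitrogen does not by itself fix the number, since this change of configuration gives a number 0.40 log units lower from compound 1 to compound 4 (beyond the scatter), and the exchange of the oxygen-containing ring group for the new group gives a number 0.40 log units lower from compound 2 to compound 4 (beyond the scatter). The first of these steps can be assigned to the single stereocentre at a saturated ring carbon, drawn S in compound 1 and R in compound 4, because nothing else separates the pair: the fact that compounds 1 and 4 differ only in the configuration as drawn. Measured against the methyl, the new group gives a number 0.10 log units lower from compound 3 to compound 4 (within the scatter), so the exchange of methyl for this group stays within the scatter in both configurations, even though the two configurations lie beyond the scatter of each other.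

The compounds shown leave open whether a pair differing at this stereocentre but carrying an amine or a carboxylic acid in place of the oxygen of the group would also separate in this assay. They also leave open whether a longer chain on the same amide-type nitrogen would stay within the scatter of compound 3.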